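This account rests on a few compounds, and the source may have more. Where it says the series, first, only, none or still open, it means among the compounds named here.

Measured so far in an ADME assay on Akata cells (Homo sapiens) for cytotoxicity, with a stated time of 7 days; a higher number here means that more compound is tolerated, a lower number that less compound is tolerated:

Compound 1 `CC(C)Nc1nc(N)nc2c1ncn2/C=C1/CC1(CO)CO`: > 24000 nM (a limit)
Compound 2 `CCCCCCCCSc1nc(N)nc2c1ncn2/C=C1/CC1(CO)CO`: > 20000 nM (a limit)

Compound 2 offers no exact number as a starting point, only the limit > 20000 nM. Compound 1 is in the same position, with the limit > 24000 nM. The next compound is compound 3 `CC(C)CNc1nc(N)nc2c1ncn2/C=C1/CC1(CO)CO`, in which octylsulfanyl leaves and isobutylamino enters on an aromatic carbon of the shared core: isobutylamino in place of octylsulfanyl on an aromatic carbon.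

Among the compounds with values here, only one measured step bears on this change: a step that the two limits leave unreadable from compound 1 to compound 2. Its size cannot be read, so it gives no measure of how far such a swap moves a result in this assay. The closest guide is compound 1, which carries isopropylamino and has the limit > 24000 nM. No step beyond the usual scatter is therefore expected, in either direction, and the expected step is a step that the limit leaves unreadable from compound 2 to compound 3. For compound 3 the estimated value is 25000 nM, with an expected range from 10000 nM to 60000 nM, and the result may well again be only a limit.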

Compound 3, half-maximal cytotoxic concentration: > 24000 nM
Compound 3 ended at the assay's limit; the forecaster's own chance of this, stated with the estimate: 85%; the middle value does not contradict the limit.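

Within the data shown here, compound 3 yields only a limit, as do compound 1 and compound 2, so no step between these compounds can be read. The compounds shown leave open the actual half-maximal cytotoxic concentration of each one, and whether isopropylamino, isobutylamino or octylsulfanyl on the shared core makes any difference in this assay.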